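Working notes: phenyl in place of phenoxy

The source may hold more compounds than are shown below. What is called first, only, known or untested is meant among the compounds shown, and "the series" means these compounds.

- compound 1 `CC(C)(C)c1ccc(Cn2cc(CCCCC(=O)NO)nn2)cc1`: 7370 nM
- compound 2 `O=C(CCCCc1cn(Cc2ccc(Oc3ccccc3)cc2)nn1)NO`: 7690 nM

In a functional assay on HT-1080 cells (Homo sapiens) for inhibition, read by MTT assay (a higher number here means a weaker inhibitor of growth, a lower number a stronger inhibitor of growth), compound 2 stands at 7690 nM, level with compound 1 at 7370 nM within the scatter. Next is compound 3 `O=C(CCCCc1cn(Cc2ccc(-c3ccccc3)cc2)nn1)NO`, with the change phenyl in place of phenoxy on an aromatic carbon. Among the measured compounds shown here, the one measured step at this place is a 1.0-fold higher number from compound 1 to compound 2 (0.02 log units; within the scatter), phenoxy in place of tert-butyl, and it stayed within the scatter. On that single step, no change beyond the scatter is expected in this assay, and the estimated step is a 1.2-fold lower number from compound 2 to compound 3 (0.07 log units; within the scatter). For compound 3 the expected value is 6500 nM, with an estimated range of 2800 nM to 15000 nM.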

Compound 3, concentration for 50% growth inhibition: 2690 nM
Compound 3: the middle estimate sits 2.4-fold (0.38 log units) above what was measured; measured number outside the range, below it.
By their numbers in this assay, from the lowest: compound 3; then compounds 1 and 2 (each within the scatter of the next).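

In this assay, the aromatic carbon para to a large group proves able to move the number: phenyl in place of phenoxy gives a 2.9-fold lower number from compound 2 to compound 3 (0.46 log units; beyond the scatter), and phenyl in place of tert-butyl gives a 2.7-fold lower number from compound 1 to compound 3 (0.44 log units; beyond the scatter). Both steps are modest, and phenoxy and tert-butyl alone, level with each other, gave no sign of this. Nothing measured here bears on the reason for these steps. Open, going by these compounds, is whether phenyl carrying a methoxy or a carboxylic acid, or a pyridine in its place, keeps this step. Also open, on these data alone, is whether a longer chain in the shared core changes it.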